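Adding a second methoxy to the shared core

A few compounds are considered here, and "the series" means these few. Any claim that something is new, unique, unknown or untested is made for them only; others in the source may bear on it.

Compound 1 `CCCCNc1nc(N)nc2cc(OC)ccc12` and compound 2 `CCCCNc1nc(N)nc2ccc(OC)cc12` carry one methoxy each on the shared core. In an ADME assay on HEK293 cells for agonist activity at Toll-like receptor 8 (Homo sapiens), read by a luciferase reporter, with a stated time of 6 h (on this read-out lower numbers stand for an effect already at smaller amounts and higher numbers for an effect only at larger amounts of compound), compound 1 gives 0.3 uM, and compound 2 gives 1.8 uM, the higher of the two numbers. Compound 3 `CCCCNc1nc(N)nc2cc(OC)c(OC)cc12` differs from compound 2 by methoxy in place of hydrogen on an aromatic carbon, so it holds both methoxy groups. No measured step between compounds lies behind this change; the step of a 2.3-fold lower number from compound 2 to compound 3 (0.35 log units; beyond the scatter) is expected to run toward a lower number in this assay, of moderate size. Compound 3 is estimated at 0.8 uM, within 0.2 uM to 3 uM.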

Compound 3, minimum effective concentration: 1.1 uM
For compound 3 the middle estimate is 1.4-fold (0.14 log units) below the measured one; low and high end bracket the measured number.
By their numbers in this assay, from the lowest: compound 1; then compounds 3 and 2 (each within the scatter of the next).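

In this assay the methoxy in place of hydrogen on an aromatic carbon, ortho to a methoxy group, gives a 1.6-fold lower number from compound 2 to compound 3 (0.21 log units; within the scatter), so at this position on compound 2 the added group makes no change that can be told from the scatter. The same kind of change read from the other side gives a 3.7-fold higher number from compound 1 to compound 3 (0.56 log units; beyond the scatter), so the outcome depends on which methoxy is already present. No measurement available here explains this difference.

Going by these compounds, whether the higher number from compound 1 belongs to methoxy specifically remains open. A fluorine, a hydroxyl or a longer alkoxy chain at this carbon would test that.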